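Swapping trifluoromethoxy for fluoro on the aroyl ring

The compounds below may be only part of what the source reports. "The series", "measured", "known", "first", "only" and "open" are said of these compounds alone.

Measured so far:
compound 1, `O=C(O)CCC(=O)N(C1CC1)[C@H]1c2ccccc2N(C(=O)c2cccc(OC(F)(F)F)c2)[C@H]2CC[C@H]21`, 18 nM;
compound 2, `O=C(O)CCC(=O)N(C1CC1)[C@H]1c2ccccc2N(C(=O)c2ccc(OC(F)(F)F)cc2)[C@H]2CC[C@H]21`, 3.9 nM;
compound 3, `O=C(O)COC(=O)N(C1CC1)[C@H]1c2ccccc2N(C(=O)c2cccc(F)c2)[C@H]2CC[C@H]21`, 13 nM.

All three were tested in a functional assay for antagonist activity at prostaglandin D2 receptor 2 (Homo sapiens), read by flow cytometry, with stated times of 10 min and 4 min; on this read-out higher numbers stand for weaker inhibition and lower numbers for stronger inhibition. Among them compound 2 gives the lowest number, that is, the strongest inhibition: compound 3 sits a little higher, and compound 1 higher still, both gaps beyond the scatter. Going by the values given here, the only one-step comparison available, a 4.6-fold lower number from compound 1 to compound 2 (0.66 log units; beyond the scatter), moves the trifluoromethoxy group from one position to another on the same ring, so it speaks to where a group sits rather than to which group is present.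

Compound 4, `O=C(O)CCC(=O)N(C1CC1)[C@H]1c2ccccc2N(C(=O)c2ccc(F)cc2)[C@H]2CC[C@H]21`, keeps the shared core of compound 2 and changes only the aroyl ring: fluoro in place of trifluoromethoxy on an aromatic carbon. Among the compounds with values here, no measured pair isolates this exchange. Within the data shown here, compound 3 carries a fluoro group but at another position and with a different linker, so its value shows only that a fluoro-bearing ring can still give a low number. Among the measured compounds shown here, with no direct precedent, a modest weakening seems the most likely outcome, estimated as a 2.6-fold higher number from compound 2 to compound 4 (0.41 log units; beyond the scatter). The estimate for compound 4 is therefore 10 nM, with a range from 3 nM to 35 nM.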

Compound 4, half-maximal inhibitory concentration: 8.9 nM
Compound 4: the middle estimate sits 1.1-fold (0.05 log units) above what was measured, within the range that was stated.
By their numbers in this assay, from the lowest: compound 2; then compounds 4, 3 and 1 (each within the scatter of the next, the first and the last beyond it).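

In this assay, the aroyl ring at this position, para to a large group, keeps a low number when fluoro, with fewer heavy atoms, replaces trifluoromethoxy: the exchange gives a 2.3-fold higher number from compound 2 to compound 4 (0.36 log units; beyond the scatter), so trifluoromethoxy is not essential here, although compound 2 stays ahead of compound 4 by a margin that the assay can resolve. The other new comparison gives a 2.0-fold lower number from compound 1 to compound 4 (0.31 log units; beyond the scatter), which shows that 4-fluorophenyl outperforms 3-(trifluoromethoxy)phenyl on this carbonyl carbon, but this step changes both the group and its place on the ring, so neither change can be credited alone. Nothing available here explains why trifluoromethoxy gives the lower number at this position.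

The compounds shown leave open whether a chloro, methoxy or trifluoromethyl group at this position, or a plain hydrogen, would give a number nearer that of compound 2 or compound 4. They also do not show what fluoro gives on the position held by trifluoromethoxy in compound 1 with the same chain, which would separate the effect of place from the effect of the group.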